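The compounds below may be only part of what the source reports. "The series", "measured", "known", "first", "only" and "open" are said of these compounds alone.

Measured so far:
compound 1, `COc1cc(-c2cc(/C=C/C(=O)c3ccc(N)cc3)[nH]n2)cc(OC)c1OC`: -90%
compound 2, `COc1cc(-c2cc(/C=C/C(=O)c3ccc(Cl)c(Cl)c3)[nH]n2)cc(OC)c1OC`: -10%
compound 3, `COc1ccc(C(=O)/C=C/c2cc(-c3cc(OC)c(OC)c(OC)c3)n[nH]2)cc1OC`: -84%

All three numbers come from a functional assay on 786-0 cells (Homo sapiens) for cytotoxicity, read by sulforhodamine B assay, with a stated time of 48 h, tested at 100 uM; a higher number here means a weaker effect of the compound at the concentration tested, a lower number a stronger effect. Compound 3 stands second highest of the three. Its nearest neighbour is compound 1, a number 6 percentage points higher from compound 1 to compound 3 (within the scatter), so the two are not separated by their numbers. Its furthest is compound 2, a number 74 percentage points lower from compound 2 to compound 3 (beyond the scatter), a clear separation, and a number 80 percentage points higher from compound 1 to compound 2 (beyond the scatter) shows the same gap from the other side.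

Compound 4, `COc1ccc(C(=O)/C=C/c2cc(-c3cc(OC)c(OC)c(OC)c3)n[nH]2)cc1`, has not yet been measured. Relative to compound 3 the change is hydrogen in place of methoxy on an aromatic carbon. Every step measured so far exchanges the whole aryl on the carbonyl carbon. The two large steps, a number 80 percentage points higher from compound 1 to compound 2 (beyond the scatter) and a number 74 percentage points lower from compound 2 to compound 3 (beyond the scatter), both involve the 3,4-dichlorophenyl, while exchanging 4-aminophenyl for 3,4-dimethoxyphenyl stays within the scatter. Going by the values given here, no measured step removes a single methoxy, so the step to compound 4 has no direct precedent; it is a smaller change than any of the aryl swaps. In this assay it is expected to give no step beyond the scatter, with some room for weakening. For compound 4 the expected value in this assay is -78%, between -95% and -45%. The expected step is a number 6 percentage points higher from compound 3 to compound 4 (within the scatter).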

Compound 4, a percentage reported as activity, at one concentration (the size of the read-out at that concentration, not a potency): -48%
Estimate against measurement, compound 4: 30 percentage points below; low and high end bracket the measured number.
By their numbers in this assay, from the lowest: compounds 1 and 3 (each within the scatter of the next); then compound 4; then compound 2.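

In this assay, going by these compounds alone, taking one methoxy off the 3,4-dimethoxyphenyl to leave 4-methoxyphenyl is a real change (a number 36 percentage points higher from compound 3 to compound 4 (beyond the scatter)), so a single group at this aromatic carbon, ortho to a methoxy group, can matter where the earlier steps exchanged only whole aryls. Compound 4 also stands clear of the weakest member of the set (a number 38 percentage points lower from compound 2 to compound 4 (beyond the scatter)), so 4-methoxyphenyl takes an intermediate place rather than joining either end of the earlier spread. The 4-aminophenyl of compound 1 also has hydrogen at this carbon, yet exchanging its amino for methoxy gives a large step (a number 42 percentage points higher from compound 1 to compound 4 (beyond the scatter)), so hydrogen at this carbon does not by itself set the weaker number, and the effect of this position depends on the group it accompanies.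

From the compounds shown here alone, whether a hydroxyl or an ethoxy at this carbon would read like the methoxy of compound 3 or like the hydrogen of compound 4 stays open, as does whether the stronger and weaker effects seen at this one concentration would hold at other concentrations. No measured property is available to account for any of these steps.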